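The compounds below may be only part of what the source reports. "The series", "measured", "known", "first", "only" and "open" are said of these compounds alone.

Of the compounds shown here, three sharing one core have been tested in a functional assay on HepG2 cells (Homo sapiens) for cytotoxicity, read by MTT assay, with a stated time of 24 h; a higher number here means a weaker inhibitor, a lower number a stronger inhibitor. Compound 1, `O=C1/C(=C/c2ccccc2F)CN(S(=O)(=O)c2ccccc2)C/C1=C\c1ccccc1F`, gives 15900 nM. Compound 2, `O=C1/C(=C/c2ccccc2F)CN(S(=O)(=O)c2ccc(F)cc2)C/C1=C\c1ccccc1F`, gives 8000 nM in this assay. Compound 3, `O=C1/C(=C/c2cccc(F)c2)CN(S(=O)(=O)c2ccc(O[N+](=O)[O-])cc2)C/C1=C\c1cccc(F)c1`, gives 8100 nM in this assay and so stands second highest of the three numbers; compound 2 is nearest to it and compound 1 furthest, but both gaps lie within the scatter, so the three compounds cannot be ordered against one another.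

Compound 4, `N#Cc1ccc(S(=O)(=O)N2C/C(=C\c3cccc(F)c3)C(=O)/C(=C/c3cccc(F)c3)C2)cc1`, has not yet been measured in this assay. It differs from compound 3 in one place: cyano in place of nitrooxy on an aromatic carbon. Going by the values given here, only one measured step bears on this change, since it is the only one that alters a substituent on the same aromatic ring: the fluoro in place of hydrogen on an aromatic carbon, which gave a 2.0-fold lower number from compound 1 to compound 2 (0.30 log units; within the scatter). Among the compounds with values here, that step stayed within the scatter, and nothing among the measured compounds shows that swapping one group for another on this ring shifts the number beyond it. Compound 4 is therefore expected to show a 1.0-fold lower number from compound 3 to compound 4 (0.01 log units; within the scatter), a step expected to remain within the scatter. Compound 4 is estimated to give about 8000 nM in this assay, with a likely range from 3500 nM to 18000 nM.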

Compound 4, half-maximal inhibitory concentration: 2600 nM
Estimate against measurement, compound 4: 3.1-fold (0.49 log units) above, and the stated range ends above it.
By their numbers in this assay, from the lowest: compound 4; then compounds 2, 3 and 1 (each within the scatter of the next).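

In this assay, the position on the aromatic ring that carries the change now proves able to move the number beyond the scatter: replacing 4-(nitrooxy)phenyl with 4-cyanophenyl gave a 3.1-fold lower number from compound 3 to compound 4 (0.49 log units; beyond the scatter) in a modest step. Going by these compounds alone, the only earlier step on this ring, fluoro in place of hydrogen, gave a 2.0-fold lower number from compound 1 to compound 2 (0.30 log units; within the scatter) and stayed within the scatter, so the compounds before this one could not show that the group at this place matters at all. No evidence is available on why the exchange of nitrooxy for cyano gives this step, and no property can be assigned to either group.

The compounds shown do not tell whether the step reflects something gained with cyano or something lost with nitrooxy, and the two steps on this ring come from compounds whose fluorine substitution on the other two aromatic rings differs, so their sizes cannot be set directly against each other. From the compounds shown here alone, it also remains open whether a methoxy group, an amine or a carboxylic acid at this place would give a number close to that of compound 3 or of compound 4.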